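Urea to amide on a pyrazole-aryl series: one change

The source may report more compounds than this note shows. Statements on the series, on what has been measured and on what is new or still open speak of the compounds shown alone.

Measured compounds:
compound 1, `COc1cc(Cl)cc(-c2nn(-c3cccc(NC(=O)Nc4ccc(Cl)c(C(F)(F)F)c4)c3)cc2-c2ccncc2)c1`, 102%
compound 2, `COc1cc(Cl)cc(-c2nn(-c3cccc(NC(=O)Nc4ccc(Cl)c(Cl)c4)c3)cc2-c2ccncc2)c1`, 96%
compound 3, `COc1cc(Cl)cc(-c2nn(-c3cccc(NC(=O)Nc4cccc(C(F)(F)F)c4)c3)cc2-c2ccncc2)c1`, 95%

In a functional assay on SK-MEL-2 cells (Homo sapiens) for inhibition, read by sulforhodamine B assay, with a stated time of 48 h, tested at 0.01 uM (a higher number here means a weaker effect of the compound at the concentration tested, a lower number a stronger effect), compound 1 gives 102%, compound 2 gives 96% and compound 3 gives 95%. All three numbers sit close together: the step of a number 6 percentage points lower from compound 1 to compound 2 (within the scatter), the step of a number 7 percentage points lower from compound 1 to compound 3 (within the scatter) and the step of a number 1 percentage points lower from compound 2 to compound 3 (within the scatter) are each within the scatter, so compound 3 stands among the others rather than apart from them, and none of the three can be called stronger or weaker than the rest.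

Compound 4, `COc1cc(Cl)cc(-c2nn(-c3cccc(NC(=O)c4cccc(C(F)(F)F)c4)c3)cc2-c2ccncc2)c1`, has not yet been measured. It differs from compound 3 in one place: 3-(trifluoromethyl)phenyl in place of (3-(trifluoromethyl)phenyl)amino on a carbonyl carbon. None of the three measured steps touches the carbonyl carbon or its neighbours; they alter only the aryl ring at the far end, and each of them moved the number by less than the scatter. For the measured compounds named here, there is therefore no measured step that directly bears on losing the amino nitrogen, and the measured ones that exist give no sign of a shift. Compound 4 is expected to remain near the numbers already seen, with a step of a number 2 percentage points higher from compound 3 to compound 4 (within the scatter) that is not beyond the scatter, so that compound 4 is estimated at 97%, within 85% to 109%.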

Compound 4, a percentage reported as activity, at one concentration (the size of the read-out at that concentration, not a potency): 52%
Compound 4: the middle estimate sits 45 percentage points above what was measured; the measured number lies below the stated range.
By their numbers in this assay, from the lowest: compound 4; then compounds 3, 2 and 1 (each within the scatter of the next).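

In this assay, the change at the carbonyl carbon does what no change on the far aryl ring did: removing only the amino nitrogen gives a number 43 percentage points lower from compound 3 to compound 4 (beyond the scatter), along with the loss of the hydrogen-bond donor counted for the group that leaves. The steps that also change the ring substituents are of similar size, a number 44 percentage points lower from compound 2 to compound 4 (beyond the scatter) and a number 50 percentage points lower from compound 1 to compound 4 (beyond the scatter), so among these compounds the read-out responds to the change at this position, while compound 1, compound 2 and compound 3 stay within the scatter of one another. Nothing available here explains why the number falls at this position.

The compounds shown leave open whether a methylene group or an oxygen atom in place of the amino nitrogen would give a similar number. They also leave open whether 3,4-dichlorophenyl or 4-chloro-3-(trifluoromethyl)phenyl directly on the same carbonyl carbon would behave as compound 4 does.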